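The source may hold more compounds than are shown below. What is called first, only, known or untested is meant among the compounds shown, and "the series" means these compounds.

Measured compounds in a functional assay on BGC-823 cells (Homo sapiens) for cytotoxicity, read by MTT assay; on this read-out lower numbers stand for stronger inhibition and higher numbers for weaker inhibition:

Compound 1, `Cc1cccc(Nc2nc(C)c(C(=O)/C=C/c3ccc(Cl)cc3)s2)c1`: compound 1 gives > 25000 nM, a limit of the assay.
Compound 2, `Cc1ccccc1Nc1nc(C)c(C(=O)/C=C/c2ccc(Cl)cc2)s1`: compound 2 gives > 25000 nM, a limit of the assay.
Compound 3, `COc1ccc(/C=C/C(=O)c2sc(Nc3ccc(Cl)cc3)nc2C)cc1`: compound 3 gives > 25000 nM, a limit of the assay.

Compound 3 thus stands only at a limit in this assay, and its value is not a number. The same holds for the other two values shown, so that the limit of > 25000 nM in this assay, at which 3 of the 3 values shown sit, is all this set offers. Among the compounds with values here, the one step that can be compared, a step that the two limits leave unreadable from compound 1 to compound 2, runs between two limits and its size cannot be read.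

Compound 4, `Cc1nc(Nc2ccc(Cl)cc2)sc1C(=O)/C=C/c1ccc(Cl)cc1`, differs from compound 3 by chloro in place of methoxy on an aromatic carbon. No measured step bears on this change: no pair among compound 1, compound 2 and compound 3 trades methoxy for chloro, and the single step shown is of unreadable size. With every value at the limit, the expectation for compound 4 in this assay is a further limit rather than a number. The step that the limit leaves unreadable from compound 3 to compound 4 is therefore expected to be small or unreadable, with no known direction. For compound 4 the estimate in this assay is 30000 nM, with a range from 10000 nM to 100000 nM, most likely again reported only as a limit.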

Compound 4, half-maximal inhibitory concentration: > 25000 nM
Compound 4 ended at the assay's limit (the forecaster's own chance of this, stated with the estimate: 75%); the middle value does not contradict the limit.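

In this assay compound 4 gives > 25000 nM, a limit and not a number. Its steps from compound 1, compound 2 and compound 3 cannot be read, and the series offers only this: the limit of > 25000 nM in this assay, at which 4 of the 4 values shown sit.

The compounds shown leave open whether chloro, methoxy or the different groups on the nitrogen shift this assay at all.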